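The source may report more compounds than this note shows. Statements on the series, on what has been measured and on what is new or still open speak of the compounds shown alone.

Values in an ADME assay on WI-38 cells (Homo sapiens) for cytotoxicity, read by MTT assay, with a stated time of 72 h; on this read-out higher numbers stand for weaker inhibition and lower numbers for stronger inhibition:
- Compound 1 `O=C(CCc1cccc2c1B(O)OC2)Nc1ccccc1`: 30000 nM
- Compound 2 `C#Cc1cccc(NC(=O)CCc2cccc3c2B(O)OC3)c1`: > 100000 nM, a limit of the assay
- Compound 3 `O=C(CCc1cccc2c1B(O)OC2)Nc1cccc(-c2ccccc2)c1`: 12000 nM

In this assay, compound 3 gives 12000 nM, the lowest of the two actual numbers, and compound 1 is its nearest neighbour. Compound 4 `O=C(CCc1cccc2c1B(O)OC2)Nc1cccc(-c2cccc(Cl)c2)c1` carries chloro in place of hydrogen on an aromatic carbon, which turns phenyl to 3-chlorophenyl. Among the measured compounds shown here, no measured step adds chloro. The nearest guides are the phenyl step, a 2.5-fold lower number from compound 1 to compound 3 (0.40 log units; beyond the scatter), and the ethynyl step, an at least 3.3-fold higher number from compound 1 to compound 2 (0.52 log units; beyond the scatter), and these two run in opposite directions. Only a small shift is therefore expected, leaning towards lower numbers, as the phenyl step did. The expected change is a 1.3-fold lower number from compound 3 to compound 4 (0.12 log units; within the scatter). For compound 4 the estimated value is 9000 nM, with an expected range of 3500 nM to 22000 nM.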

Compound 4, half-maximal inhibitory concentration: 58000 nM
The estimate for compound 4 lay 6.4-fold (0.81 log units) below the measured number; measured number outside the range, above it.
By their numbers in this assay, from the lowest: compound 3; then compounds 1 and 4 (each within the scatter of the next). At a limit, above all of these: compound 2.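

In this assay, turning phenyl to 3-chlorophenyl gives a 4.8-fold higher number from compound 3 to compound 4 (0.68 log units; beyond the scatter) and so reverses the direction of the phenyl step, which gave a 2.5-fold lower number from compound 1 to compound 3 (0.40 log units; beyond the scatter). The 3-chlorophenyl group in place of hydrogen gives a 1.9-fold higher number from compound 1 to compound 4 (0.29 log units; within the scatter), so the lower number seen with phenyl does not carry over. The 3-chlorophenyl group in place of ethynyl gives an at least 1.7-fold lower number from compound 2 to compound 4 (0.23 log units; that floor lies within the scatter), and this step shows no more than that floor. Compound 2 stands at a limit: the limit of > 100000 nM in this assay, at which 1 of the 4 values shown sits.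

From the compounds shown here alone, whether this rise is particular to chloro stays open, since a methyl, a methoxy or an amine in its place could show otherwise. Going by these compounds, the effect of chloro elsewhere on that ring also remains unknown.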